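The source may report more compounds than this note shows. Statements on the series, on what has been measured and on what is new or still open speak of the compounds shown alone.

Measured in a functional assay on BT-549 cells (Homo sapiens) for inhibition; a higher number here means a weaker inhibitor of growth, a lower number a stronger inhibitor of growth:
- compound 1 `NS(=O)(=O)c1ccc(/C=C/c2ccc(O)c(O)c2)cc1`: 4130 nM
- compound 2 `COc1cccc(/C=C/c2ccc(S(N)(=O)=O)cc2)c1`: 6380 nM
- compound 3 `NS(=O)(=O)c1ccc(/C=C/c2ccc(F)cc2)cc1`: 205 nM

Compound 3 holds the lowest number of the three, and both others lie beyond the scatter from it. Compound 4 `CN(C)c1ccc(/C=C/c2ccc(S(N)(=O)=O)cc2)cc1` carries dimethylamino in place of fluoro on an aromatic carbon, para to a large group: dimethylamino in place of fluoro on an aromatic carbon. Within the data shown here, no measured pair isolates this change, so the data offer only indirect guidance. Compound 1 at 4130 nM and compound 2 at 6380 nM both stand well above compound 3, which suggests that its low number may not carry over to a new group. The expected step is a 3.9-fold higher number from compound 3 to compound 4 (0.59 log units; beyond the scatter), a moderate rise beyond the scatter. For compound 4 the estimated value is 800 nM, with an expected range from 120 nM to 5000 nM.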

Compound 4, concentration for 50% growth inhibition: 2140 nM
Compound 4: the middle estimate sits 2.7-fold (0.43 log units) below what was measured; low and high end bracket the measured number.
By their numbers in this assay, from the lowest: compound 3; then compounds 4, 1 and 2 (each within the scatter of the next, the first and the last beyond it).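

Among these compounds, putting dimethylamino in place of fluoro on this aromatic carbon, para to a large group, gives a 10-fold higher number from compound 3 to compound 4 (1.02 log units; beyond the scatter) in this assay, the first reading of a single change at this place. The result in this assay therefore depends strongly on which of these two groups sits there, with the fluoro of compound 3 far ahead. No evidence at hand accounts for this step. As far as these compounds go, it remains open whether chloro, a primary amine or a methoxy group at this same place would keep the low number of compound 3 at 205 nM, or whether fluoro stands alone in doing so.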